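The source may report more compounds than this note shows. Statements on the series, on what has been measured and on what is new or still open speak of the compounds shown alone.

Series notes. Compound 1 `CN(C)CCCNc1c(C(=O)NCc2ccc(F)cc2)nc(Br)c2cccnc12` carries a (3-(dimethylamino)propyl)amino group on the shared core; in a functional assay on MDA-MB-435 cells (Homo sapiens) for cytotoxicity, read by MTT assay, with a stated time of 72 h (on this read-out lower numbers stand for stronger inhibition and higher numbers for weaker inhibition), compound 1 gives 7000 nM. Compound 2 `N[C@H]1CC[C@H](Nc2c(C(=O)NCc3ccc(F)cc3)nc(N3CCCCC3)c3cccnc23)CC1`, tested in this assay, gives 5000 nM. Among the compounds with values here, these two numbers sit within the usual scatter of each other, so the measured pair offers no separation between compound 1 and compound 2, and no single-point step between measured compounds is available to guide the next change.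

Compound 3 `Cc1ccc(S(=O)(=O)Oc2c(C(=O)NCc3ccc(F)cc3)nc(Br)c3cccnc23)cc1` is the untested member. It differs from compound 1 as follows: ((4-methylphenyl)sulfonyl)oxy in place of (3-(dimethylamino)propyl)amino on an aromatic carbon. The (3-(dimethylamino)propyl)amino group gives way to a ((4-methylphenyl)sulfonyl)oxy group at the same aromatic carbon.

Within the data shown here, with no measured step of this kind to lean on, the expectation for compound 3 in this assay is a move toward a higher number, beyond the scatter but modest, giving an estimated step of a 2.3-fold higher number from compound 1 to compound 3 (0.36 log units; beyond the scatter). Compound 3 is therefore estimated at 16000 nM in this assay, with a range from 5000 nM to 45000 nM. A limit reading for compound 3 is possible.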

Compound 3, half-maximal inhibitory concentration: > 20000 nM
Compound 3 was reported as a limit; the forecaster's own chance of this, stated with the estimate: 25%; middle value at least 1.2-fold (0.09 log units) away from the limit.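

Compound 3 gives only a limit of the assay: the limit of > 20000 nM in this assay, at which 1 of the 3 values shown sits. Read against that limit, the aromatic carbon that carries the (3-(dimethylamino)propyl)amino group in compound 1 now has its first single-place step in this assay, an at least 2.8-fold higher number from compound 1 to compound 3 (0.45 log units; beyond the scatter), so placing ((4-methylphenyl)sulfonyl)oxy there moves the read-out toward weaker inhibition, beyond the scatter, which the pair of compound 1 and compound 2 could not show. The step fixes only a lower bound on size, and it combines several differences at one place: a chain with no ring leaves, a group with an aromatic ring of carbon only enters, and the hydrogen-bond donor count changes, with no way to tell these apart.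

Still open, on these data alone, is whether the shift follows from losing the (3-(dimethylamino)propyl)amino group or from adding the ((4-methylphenyl)sulfonyl)oxy group, a question that a plain primary amine or a hydroxyl group on the same aromatic carbon, with the bromo group kept, would help to separate. The role of the bromo group on its own also stays unresolved, as compound 2 differs from compound 1 in more than one place.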